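The source may report more compounds than this note shows. Statements on the series, on what has been measured and on what is new or still open speak of the compounds shown alone.

Measured in a functional assay on MDA-MB-436 cells (Homo sapiens) for antiproliferative activity, read by MTT assay, with a stated time of 48 h; a higher number here means a weaker inhibitor, a lower number a stronger inhibitor:
- compound 1 `CN1CCN(c2ccc(-c3cc4c(N5CCN(C(=O)Nc6ccc(Cl)cc6)CC5)ncnc4s3)cc2)CC1`: 9270 nM
- compound 2 `COc1ccccc1NC(=O)N1CCN(c2ncnc3sc(-c4ccc(N5CCN(C)CC5)cc4)cc23)CC1`: 26300 nM

Compound 2 carries the higher number of the pair, so it is the weaker inhibitor in this assay. The next compound to consider is compound 3 `CN1CCN(c2ccc(-c3cc4c(N5CCN(C(=O)Nc6ccc(F)cc6F)CC5)ncnc4s3)cc2)CC1`, with one change from compound 2: 2,4-difluorophenyl in place of 2-methoxyphenyl on an amide-type nitrogen. In words, this is 2,4-difluorophenyl in place of 2-methoxyphenyl on an amide-type nitrogen.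

For the measured compounds named here, only one measured step bears on this place: a 2.8-fold higher number from compound 1 to compound 2 (0.45 log units; beyond the scatter), with 2-methoxyphenyl in place of 4-chlorophenyl. Compound 3 also gives up the 2-methoxyphenyl, but no 2,4-difluorophenyl value exists yet, so the evidence is thin. A modest move towards a lower number is expected, of similar size to that step but in the reverse direction. The estimated step is a 2.2-fold lower number from compound 2 to compound 3 (0.34 log units; beyond the scatter). For compound 3 the expected value is 12000 nM, with an estimated range of 5000 nM to 28000 nM.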

Compound 3, half-maximal inhibitory concentration: 20200 nM
The estimate for compound 3 lay 1.7-fold (0.23 log units) below the measured number; the measured number falls inside the stated range.
By their numbers in this assay, from the lowest: compound 1; then compounds 3 and 2 (each within the scatter of the next).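

In this assay, replacing 2-methoxyphenyl with 2,4-difluorophenyl on the amide-type nitrogen gives a 1.3-fold lower number from compound 2 to compound 3 (0.11 log units; within the scatter), so this assay does not separate these two aryl groups. Replacing 4-chlorophenyl with 2,4-difluorophenyl gives a 2.2-fold higher number from compound 1 to compound 3 (0.34 log units; beyond the scatter), which adds a second aryl group that falls short of 4-chlorophenyl and leaves compound 1 with the lowest number of the three, at 9270 nM. No supporting data are available to account for this ranking.

Going by these compounds, it remains open whether the advantage of 4-chlorophenyl is specific to chlorine, which a comparison with 4-fluorophenyl, 4-bromophenyl or unsubstituted phenyl would test. Also open, on these data alone, is whether any aryl group is needed on this nitrogen, or whether cyclohexyl or a short alkyl chain would give a similar number.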